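Removing a methyl from an oxygen: what compound 4 may show

The source may report more compounds than this note shows. Statements on the series, on what has been measured and on what is new or still open speak of the compounds shown alone.

Measured so far:
compound 1 `Nc1nc(Cc2ccccc2)nc2cn(-c3ccccc3O)nc12` 19%
compound 2 `COc1ccccc1-n1cc2nc(CCCc3ccccc3)nc(N)c2n1` 6%
compound 3 `Nc1nc(Cc2ccccc2)nc2cn(Cc3ccccc3)nc12` 15%

Compound 2 gives the lowest of the three numbers in an assay on CHO cells for displacement of a labelled ligand from adenosine receptor A3 (Homo sapiens), read by scintillation counting, with a stated time of 60 min, tested at 1 uM; on this read-out lower numbers stand for less inhibition and higher numbers for more inhibition at the one concentration tested (going by the name of the read-out). Its nearest neighbour is compound 3, whose value lies within the scatter of it, while compound 1 stands beyond the scatter above it. Compound 4 `Nc1nc(CCCc2ccccc2)nc2cn(-c3ccccc3O)nc12` is not yet measured. It differs from compound 2 in one place: hydrogen in place of methyl on an oxygen on an aromatic ring.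

Among the compounds with values here, only one single-point step has been measured, a number 4 percentage points lower from compound 1 to compound 3 (within the scatter), and it concerns a different change on an aromatic nitrogen. Within the data shown here, no measured pair isolates the exchange of methyl for hydrogen on the oxygen. Among the measured compounds shown here, compound 1 and compound 2 differ in two places at once, so their values show only that the compound carrying the hydroxy group and the shorter link sits higher than the compound carrying the methoxy group and the longer link.

For the measured compounds named here, with no step bearing directly on the change, only a small upward shift is expected, a number 6 percentage points higher from compound 2 to compound 4 (within the scatter), and it may well stay within the scatter. Compound 4 is therefore estimated at 12%, with a range from 0% to 28%.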

Compound 4, a percentage reported as inhibition, at one concentration (the size of the read-out at that concentration, not a potency): 5%
Compound 4: middle estimate off by 7 percentage points, on the high side, within the range that was stated.
By their numbers in this assay, from the lowest: compounds 4, 2, 3 and 1 (each within the scatter of the next, the first and the last beyond it).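

In this assay, hydrogen in place of methyl on an oxygen on an aromatic ring gives a number 1 percentage points lower from compound 2 to compound 4 (within the scatter), so with the longer chain in place this position shows no measurable response to the exchange of methoxy for hydroxy. Within the data shown here, the second new pair holds the 2-hydroxyphenyl group fixed and isolates the chain for the first time: phenethyl in place of phenyl on a saturated chain carbon bound to an aromatic carbon gives a number 14 percentage points lower from compound 1 to compound 4 (beyond the scatter), a modest step, and the only one of the two that passes beyond the scatter. Nothing available explains either step.

Among these compounds, whether methoxy and hydroxy would also read alike on the shorter chain of compound 1 stays open, since the only pair for this exchange carries the longer chain. On these data alone, it is equally open what an amine or an ethoxy group would give in place of the hydroxy, and whether a still longer chain would continue the step seen with phenethyl or leave the number where it stands.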